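The source may report more compounds than this note shows. Statements on the series, on what has been measured and on what is new or still open speak of the compounds shown alone.

Compound 1 `CCOc1ccccc1-c1ccc(-c2nc3cnccc3c(N[C@H](CC)C(N)=O)c2C#N)cc1` gives 3 in a physicochemical assay for lipophilicity, read by HPLC, at pH 7.5; on this read-out higher numbers stand for higher lipophilicity and lower numbers for lower lipophilicity.
Compound 2 `CC[C@@H](Nc1c(C#N)c(-c2ccc(-c3cccc(C)c3)cc2)nc2cnccc12)C(N)=O` gives 3.
Compound 3 `CC[C@@H](Nc1c(C#N)c(-c2ccc(-c3cccc(Cl)c3)cc2)nc2cnccc12)C(N)=O` gives 3.1.

Compound 3 holds the highest number of the three, yet its gaps to compound 1 and to compound 2 both lie within the scatter, so no order among the three can be read. The measured steps of no change at the digits printed from compound 1 to compound 2 (within the scatter), a number 0.10 log units higher from compound 1 to compound 3 (within the scatter) and a number 0.10 log units higher from compound 2 to compound 3 (within the scatter) each exchange one outer aromatic group for another and all stay within the scatter. Compound 4 `CC[C@@H](Nc1c(C#N)c(-c2ccc(-c3ccc(Cl)cc3)cc2)nc2cnccc12)C(N)=O` arises from compound 3 by 4-chlorophenyl in place of 3-chlorophenyl on an aromatic carbon. For the measured compounds named here, no measured step exchanges 3-chlorophenyl for 4-chlorophenyl, so the change has no direct precedent here; the narrow spread across the measured exchanges suggests no step beyond the scatter. Compound 4 is therefore expected to give 3.1 (range 2.8 to 3.4) in this assay, an estimated step of no change at the digits printed from compound 3 to compound 4 (within the scatter).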

Compound 4, distribution coefficient: 3.1
Compound 4: middle estimate and measured number agree at the digits printed; the range from low to high includes it.
By their numbers in this assay, from the lowest: compounds 1, 2, 3 and 4 (each within the scatter of the next).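

In this assay the exchange of 3-chlorophenyl for 4-chlorophenyl gives no change at the digits printed from compound 3 to compound 4 (within the scatter) and so, with the same atoms joined differently, these two placings of the chlorine on the outer ring cannot be told apart. The steps of a number 0.10 log units higher from compound 2 to compound 4 (within the scatter) and a number 0.10 log units higher from compound 1 to compound 4 (within the scatter) put 4-chlorophenyl alongside the 3-methylphenyl and 2-ethoxyphenyl groups as well. On these data alone, whether an amine or a carboxylic acid on this outer ring would move the number beyond the scatter stays open. No further evidence bears on these results.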